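A few compounds are considered here, and "the series" means these few. Any claim that something is new, unique, unknown or untested is made for them only; others in the source may bear on it.

The measured compounds:

Compound 1, `C=CC1=C(C(=O)Nc2ccc(C)cc2)C(c2ccc(F)cc2)OC1`. In a functional assay on SW480 cells (Homo sapiens) for cytotoxicity, read by MTT assay, with a stated time of 24 h (on this read-out higher numbers stand for weaker inhibition and lower numbers for stronger inhibition), compound 1 gives only the limit > 100000 nM.

Compound 2, `C=CC1=C(C(=O)Nc2ccccc2)C(c2ccc(F)cc2)OC1`. In this assay compound 2 also gives only the limit > 100000 nM.

Compound 3, `C=CC1=C(C(=O)NC2CCCCC2)C(c2ccc(F)cc2)OC1`. In this assay compound 3 likewise gives only the limit > 100000 nM.

Compound 3 therefore stands nowhere on a scale of numbers: its result is a limit, as is every other result shown, which is the point made by the limit of > 100000 nM in this assay, at which 3 of the 3 values shown sit. The three steps among the measured compounds, a step that the two limits leave unreadable from compound 1 to compound 2, a step that the two limits leave unreadable from compound 1 to compound 3 and a step that the two limits leave unreadable from compound 2 to compound 3, all run between limits and so have no readable size.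

Compound 4 is `C=CC1=C(C(=O)O)C(c2ccc(F)cc2)OC1`. It differs from compound 3 in this way: hydroxy in place of cyclohexylamino on a carbonyl carbon. Within the data shown here, two of the measured steps alter the substituent on the amide-type nitrogen without leaving the limit, but none touches the carbonyl carbon itself, so no measured step bears directly on this change. Given that every value so far sits at the limit, compound 4 is expected to remain there as well, with a step that the limit leaves unreadable from compound 3 to compound 4 expected in this assay rather than a measurable gain. For compound 4 the estimate is 150000 nM, within a range from 50000 nM to 500000 nM.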

Compound 4, half-maximal inhibitory concentration: > 100000 nM
Compound 4 gave a limit, no number (the forecaster's own chance of this, stated with the estimate: 85%); the middle value does not contradict the limit.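

In this assay compound 4 gives > 100000 nM, which is a limit and not a number. Its steps to compound 1, compound 2 and compound 3 therefore cannot be read: the limit of > 100000 nM in this assay, at which 4 of the 4 values shown sit. The compounds shown leave open what structural change, if any, would yield a numerical value in this assay.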